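The compounds below may be only part of what the source reports. "The series", "measured", "known", "first", "only" and "open" are said of these compounds alone.

Measured so far in an in vitro functional assay on cells for antagonist activity at B1 bradykinin receptor (Homo sapiens), read by luminescence and calcium flux, with a stated time of 2 h; on this read-out higher numbers stand for weaker inhibition and lower numbers for stronger inhibition:
compound 1 `Cc1ccc(S(=O)(=O)N2C=CNC(=O)[C@H]2CC(=O)N[C@@H]2CCCc3ccccc32)cc1` gives 3.3 nM
compound 2 `Cc1ccc(S(=O)(=O)N2C=CNC(=O)[C@H]2CC(=O)NC2CCNc3ccccc32)cc1` gives 21.6 nM
compound 3 `CC(=O)N1CCC(NC(=O)C[C@@H]2C(=O)NC=CN2S(=O)(=O)c2ccc(C)cc2)c2ccccc21` gives 72.2 nM

Among these three numbers compound 2 stands second highest. Its nearest neighbour is compound 3, separated by a 3.3-fold higher number from compound 2 to compound 3 (0.52 log units; beyond the scatter); its furthest is compound 1, separated by a 6.5-fold higher number from compound 1 to compound 2 (0.82 log units; beyond the scatter) read in reverse.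

Compound 4 `Cc1ccc(S(=O)(=O)N2C=CNC(=O)[C@H]2CC(=O)NC2CCCCC2C)cc1` is not yet measured. Against compound 2 the change is a group of 7 heavy atoms (7 carbon; one six-membered non-aromatic ring of carbon only) in place of a group of 10 heavy atoms (9 carbon, 1 nitrogen; one six-membered non-aromatic ring with 1 hetero atom, one six-membered aromatic ring of carbon only), on an amide-type nitrogen. Among the measured compounds shown here, two measured steps touch the same part of the molecule. Swapping the all-carbon bicycle for the nitrogen-bearing one gave a 6.5-fold higher number from compound 1 to compound 2 (0.82 log units; beyond the scatter); adding acetyl to that ring nitrogen gave a 3.3-fold higher number from compound 2 to compound 3 (0.52 log units; beyond the scatter). Both point the same way: the variants carrying the ring nitrogen read higher than the all-carbon one. For the measured compounds named here, compound 4 removes that ring nitrogen, as compound 1 has none, but also gives up the aromatic ring altogether, and no measured pair shows what that loss does. The expectation is therefore a move toward lower numbers, held modest and with a wide band, a step of about a 1.4-fold lower number from compound 2 to compound 4 (0.16 log units; within the scatter) being expected. Compound 4 is thus expected to come in near 15 nM, within 4 nM to 60 nM.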

Compound 4, half-maximal inhibitory concentration: 25.9 nM
The estimate for compound 4 lay 1.7-fold (0.24 log units) below the measured number; the range from low to high includes it.
By their numbers in this assay, from the lowest: compound 1; then compounds 2 and 4 (each within the scatter of the next); then compound 3.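

In this assay, 2-methylcyclohexyl on the amide-type nitrogen gives a 1.2-fold higher number from compound 2 to compound 4 (0.08 log units; within the scatter), so in this pair a group with no aromatic ring and no ring nitrogen cannot be told apart from the nitrogen-bearing group it replaces. Against the all-carbon 1,2,3,4-tetrahydronaphthalen-1-yl, the same change gives a 7.8-fold higher number from compound 1 to compound 4 (0.89 log units; beyond the scatter), which shows that the absence of a ring nitrogen does not by itself bring a compound to the number of compound 1, since compound 4 also has no ring nitrogen and still reads well above it. Nothing to hand gives a cause for either step, so these notes record only the numbers and the groups that changed.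

Still open, on these data alone, is what the methyl of 2-methylcyclohexyl contributes, which a plain cyclohexyl group would address, and whether a benzyl group, with an aromatic ring on a short carbon link, would read closer to compound 1 or to compound 4. Compound 4 is also drawn without defined stereochemistry on the 2-methylcyclohexyl group, leaving open how its separate cis and trans forms, each as a single enantiomer, would read.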